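The source may report more compounds than this note shows. Statements on the series, on what has been measured and on what is new or still open speak of the compounds shown alone.

Compound 1 `CO/C(O)=C1\C(C)=NC(C)=C([N+](=O)[O-])C1c1ccncc1` carries a methyl on the ester oxygen and a pyridin-4-yl on the saturated ring carbon. In a functional assay (cardiac atrium) for agonist activity, with Cavia porcellus as the target (a higher number here means that more compound is needed for the effect, a lower number that less compound is needed), compound 1 gives 48500 nM. Two close relatives have been measured alongside it. Compound 3 `CO/C(O)=C1\C(C)=NC(C)=C([N+](=O)[O-])C1c1cccnc1` gives 70000 nM in this assay, and the move a 1.4-fold higher number from compound 1 to compound 3 (0.16 log units; within the scatter) tells nothing beyond the noise. Compound 2 `CC1=NC(C)=C([N+](=O)[O-])C(c2cccnc2)/C1=C(\O)OC(C)C` gives 28500 nM in this assay; its value and that of compound 1 also lie within the scatter of one another, so compound 1 cannot be set apart from either neighbour on the numbers shown.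

Compound 4 `COCCO/C(O)=C1\C(C)=NC(C)=C([N+](=O)[O-])C1c1ccncc1` differs from compound 1 in one place: methoxymethyl in place of hydrogen on a saturated chain carbon bound to an oxygen on an unsaturated carbon. For the measured compounds named here, the only measured step that speaks to the ester alkyl is a 2.5-fold higher number from compound 2 to compound 3 (0.39 log units; beyond the scatter), where the larger group on the oxygen went with the lower number. The new group is larger still and of a different kind, so the step is only a loose guide, but on its basis a modest lowering of the number for compound 4 is expected, estimated as a 1.9-fold lower number from compound 1 to compound 4 (0.29 log units; within the scatter). Compound 4 is therefore estimated to give 25000 nM in this assay, with a likely range from 8000 nM to 80000 nM.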

Compound 4, half-maximal effective concentration: 37700 nM
Compound 4: middle estimate off by 1.5-fold (0.18 log units), on the low side; the measured number falls inside the stated range.
By their numbers in this assay, from the lowest: compounds 2, 4, 1 and 3 (each within the scatter of the next, the first and the last beyond it).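

In this assay, going from methyl to 2-methoxyethyl on the oxygen on an unsaturated carbon gives a 1.3-fold lower number from compound 1 to compound 4 (0.11 log units; within the scatter), so with pyridin-4-yl held fixed, this position accepts the longer chain with its added oxygen without a shift that can be told from the scatter. For the compounds shown here, the only earlier step at this oxygen, a 2.5-fold higher number from compound 2 to compound 3 (0.39 log units; beyond the scatter), lay beyond the scatter, but it compared isopropyl with methyl and was read with pyridin-3-yl on the saturated ring carbon, and the new step does not add a second case of that size. The trend suggested by isopropyl and methyl therefore does not carry over to 2-methoxyethyl, and nothing given here accounts for the result.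

The compounds shown leave open whether 2-methoxyethyl would behave the same way with pyridin-3-yl on the saturated ring carbon, since compound 4 is paired only with a pyridin-4-yl relative. They also leave open whether a 2-aminoethyl group, a chain ending in a carboxylic acid or a longer alkyl chain at this oxygen would move the number beyond the scatter.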